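Removing One Chloro Group: Compound 2 to Compound 3

The source may report more compounds than this note shows. Statements on the series, on what has been measured and on what is new or still open speak of the compounds shown alone.

Measured so far:
compound 1, `ClCc1ccc(Cn2cnc3c(Cl)ncnc32)cc1`, 95500 nM
compound 2, `ClCc1ccccc1Cn1cnc2c(Cl)nc(Cl)nc21`, 5880 nM

The numbers come from a functional assay on KM12 cells (Homo sapiens) for cytotoxicity, read by sulforhodamine B assay, with a stated time of 48 h; a lower number here means that less compound is tolerated, a higher number that more compound is tolerated. Of the two compounds measured in it, compound 2 gives 5880 nM and stands lowest; compound 1 gives 95500 nM, a higher number, and the gap between the two lies beyond the usual scatter. The two compounds differ in more than one place, so their two values show only that the cells tolerate less of compound 2 than of compound 1.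

Compound 3, `ClCc1ccccc1Cn1cnc2c(Cl)ncnc21`, has not yet been measured in this assay. It differs from compound 2 in one place: hydrogen in place of chloro on an aromatic carbon. One chlorine leaves the shared core and a hydrogen takes its place; the benzyl part carrying the chloromethyl group is unchanged.

Among the measured compounds shown here, no step between measured compounds changes only this group, so the direction has to be guessed. Compound 1 likewise lacks this chloro group and gives 95500 nM, a high number. On that ground alone the number for compound 3 is expected to rise, by an estimated 5.1-fold higher number from compound 2 to compound 3 (0.71 log units; beyond the scatter). For compound 3 the expected value is 30000 nM, within a range of 8000 nM to 100000 nM.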

Compound 3, concentration lethal to 50% of the cells: 66100 nM
The estimate for compound 3 lay 2.2-fold (0.34 log units) below the measured number; low and high end bracket the measured number.
By their numbers in this assay, from the lowest: compound 2; then compounds 3 and 1 (each within the scatter of the next).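

In this assay, putting hydrogen in place of chloro on the aromatic carbon between two ring nitrogen atoms gives an 11-fold higher number from compound 2 to compound 3 (1.05 log units; beyond the scatter), a large step for the loss of a single heavy atom. Compounds 1 and 2 differ in more than one place, so their values could not be tied to this chloro group, whereas here the rest of the structure, including the benzyl part carrying the chloromethyl group, stays the same, and the presence of this one chlorine clearly separates the two numbers: the cells tolerate far less of compound 2 than of compound 3. Nothing available explains why this single replacement has so large an effect on the cells.

Going by these compounds, with only chloro and hydrogen seen at this position, it remains open whether the high tolerance belongs to hydrogen alone or whether an amine, a methoxy group or a bromo group there would give a number nearer that of compound 2 or that of compound 3. On these data alone, the effect of replacing the other chloro group on the shared core also remains open.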